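The compounds below may be only part of what the source reports. "The series", "measured", "known", "first", "only" and "open" are said of these compounds alone.

In an ADME assay on L929 cells (Mus musculus) for cytotoxicity, read by resazurin assay, with a stated time of 72 h (on this read-out higher numbers stand for weaker inhibition and lower numbers for stronger inhibition), compound 1 `O=C(/C=C/c1ccc2c(c1)B(O)OC2)c1ccc(Br)cc1` reads > 10 ug/mL as a limit of the assay and not a number. Compound 2 `O=C(/C=C/c1ccc2c(c1)B(O)OC2)c1cccc(F)c1` reads > 10 ug/mL in this assay and this too is only a limit. Compound 2 therefore has no exact position, and the evidence so far is the limit of > 10 ug/mL in this assay, at which 2 of the 2 values shown sit, and nothing more. Compound 3 `O=C(/C=C/c1ccc2c(c1)B(O)OC2)c1cccc(O)c1` differs from compound 2 by one exchange, hydroxy in place of fluoro on an aromatic carbon, meta to a large group hydroxy in place of fluoro on an aromatic carbon and the rest of the molecule stays the same. Among the compounds with values here, the only measured step is a step that the two limits leave unreadable from compound 1 to compound 2 and it offers no size to borrow, so no change beyond the usual scatter is expected in this assay and no direction is favoured. The expected move is a step that the limit leaves unreadable from compound 2 to compound 3 as an estimate only. Compound 3 is estimated at 15 ug/mL with an expected range from 6 ug/mL to 40 ug/mL and may again report only a limit.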

Compound 3, half-maximal inhibitory concentration: 7.56 ug/mL
Estimate against measurement, compound 3: 2.0-fold (0.30 log units) above; low and high end bracket the measured number.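

In this assay, within the data shown here, hydroxy on this aromatic carbon gives the first exact number, while the earlier compounds offered only limits. Exchanging fluoro for hydroxy shows an at least 1.3-fold lower number from compound 2 to compound 3 (0.12 log units; that floor lies within the scatter), and exchanging 4-bromophenyl for 3-hydroxyphenyl shows an at least 1.3-fold lower number from compound 1 to compound 3 (0.12 log units; that floor lies within the scatter). Both steps are only floors that lie within the usual scatter, so neither the true size of either change nor a real gain in cytotoxicity is established, and the comparison rests on a shared limit rather than on numbers: the limit of > 10 ug/mL in this assay, at which 2 of the 3 values shown sit.

From the compounds shown here alone, whether an amine or a methoxy group on this same aromatic carbon would also bring a reading under the limit remains open. Going by these compounds, how far the true values of compound 1 and compound 2 lie from that of compound 3 also remains unknown.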